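The compounds below may be only part of what the source reports. "The series", "measured", "known", "first", "only" and "open" are said of these compounds alone.

Measured so far, all in a functional assay on RKE cells for antagonist activity at Vasoactive intestinal polypeptide receptor 1 (Rattus norvegicus), read by HTRF and cAMP accumulation, with stated times of 10 min and 30 min; on this read-out higher numbers stand for weaker inhibition and lower numbers for stronger inhibition:

- compound 1, `CCC(=O)Nc1sc2c(c1C#N)CCCC2`: 12000 nM
- compound 3, `CC(C)c1cc(C(C)(C)C)cc(-c2ccccc2-c2ccccc2)c1CO`: 3200 nM
- compound 2, `CC(C)c1cc(C(C)(C)C)cc(-c2cccc(C(F)(F)F)c2)c1CO`: reported only as a limit of the assay, > 50000 nM

Two numbers and one limit make up the whole of what is known about this series in this assay. Compound 1 holds the higher of the two numbers; compound 3 sits at the lower one, and the gap between them is beyond the scatter. Within the data shown here, no step between compounds differing in a single place has been measured, so nothing can be said about the two biaryl compounds beyond what their two values show. Of compound 2 only the limit of > 50000 nM in this assay, at which 1 of the 3 values shown sits, is recorded.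

The next compound is compound 4, `CC(=O)Nc1sc2c(c1C#N)CCCC2`. It keeps the core of compound 1 and differs from it by hydrogen in place of methyl on a saturated chain carbon bound to a carbonyl carbon: in words, hydrogen in place of methyl on a saturated chain carbon bound to a carbonyl carbon, propanoyl to acetyl.

Among the measured compounds shown here, no measured step of this kind exists here. The change is the removal of a single carbon from an acyl chain, and the expectation is a step of no more than the usual scatter, if anything toward a higher number. The expected step of a 1.3-fold higher number from compound 1 to compound 4 (0.12 log units; within the scatter) is therefore small. Compound 4 is estimated at 16000 nM in this assay, with a range from 6000 nM to 45000 nM.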

Compound 4, half-maximal inhibitory concentration: 13000 nM
Beside the measured number, compound 4's estimate is 1.2-fold (0.09 log units) above it; the range from low to high includes it.
By their numbers in this assay, from the lowest: compound 3; then compounds 1 and 4 (each within the scatter of the next). At a limit, above all of these: compound 2.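

Propanoyl to acetyl gives a 1.1-fold higher number from compound 1 to compound 4 (0.03 log units; within the scatter) in this assay, so the two compounds cannot be told apart on this read-out. Among these compounds, this is the first step that can be read at a single place, which the earlier compounds could not supply: at this saturated chain carbon bound to a carbonyl carbon, hydrogen in place of methyl gives a step within the scatter, and so the terminal methyl of the propanoyl group shows no measurable contribution to the number in this pair. No measured property among the data shown bears on this step, and no cause can be assigned to it.

Still open, going by these compounds, is whether the flat reading holds only for this small pair of acyl groups, or whether a longer chain such as butanoyl, a branched chain such as isobutyryl, or a terminal amine or carboxylic acid on the acyl chain would move the number beyond the scatter. Also open, on these data alone, is how much the nitrile and the amide hydrogen of the shared core matter, and compounds 2 and 3 differ from this pair in more than one place, so they give no guide on either question.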